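The source may report more compounds than this note shows. Statements on the series, on what has been measured and on what is new or still open speak of the compounds shown alone.

For the measured compounds named here, the series starts from compound 1 `COC(=O)C1=C(N)Oc2c(OC)cc(Br)cc2C1CC(=O)c1ccc(Cl)cc1` and compound 2 `COC(=O)C1=C(N)Oc2ccc(Br)cc2C1CC(=O)c1ccccc1`, both carrying the same core and differing in more than one place, so no single step between them can be read. In a functional assay on MCF7 cells (Homo sapiens) for antiproliferative activity, read by sulforhodamine B assay, with a stated time of 72 h, tested at 30 uM (a lower number here means a stronger effect, a higher number a weaker effect of the compound at the concentration tested), compound 1 gives 33.8%, and in the same assay compound 2 gives 41.3%. Compound 2 holds the higher of the two numbers recorded so far, but the gap to compound 1 falls within the usual scatter of such measurements, so the two compounds cannot be told apart on this evidence.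

The account now follows the step from compound 2 to compound 3 `COC(=O)C1=C(N)Oc2ccc(Br)cc2C1CC(=O)c1ccc(Cl)cc1`, which has not yet been measured in this assay. The change is chloro in place of hydrogen on an aromatic carbon. Going by the values given here, no measured pair in this set isolates that change, so its effect is unknown here. Given that compound 1, which also carries the chloro group, shows 33.8%, the step of a number 5.3 percentage points lower from compound 2 to compound 3 (within the scatter) is expected to be small and to stay within the scatter. Compound 3 is therefore estimated at 36%, with a range from 22% to 50%.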

Compound 3, a percentage reported as activity, at one concentration (the size of the read-out at that concentration, not a potency): 32.4%
For compound 3 the middle estimate is 3.6 percentage points above the measured one, within the range that was stated.
By their numbers in this assay, from the lowest: compounds 3, 1 and 2 (each within the scatter of the next).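

The step from phenyl to 4-chlorophenyl, with chloro on an aromatic carbon para to a large group, can now be read on its own in this assay: it gives a number 8.9 percentage points lower from compound 2 to compound 3 (within the scatter), so at this concentration the chloro group cannot be told apart from hydrogen at this position. The second pair isolates a different place on the shared core, where hydrogen in place of methoxy on an aromatic carbon gives a number 1.4 percentage points lower from compound 1 to compound 3 (within the scatter), so the methoxy group cannot be told apart from hydrogen there either, and neither single change separates its two compounds in this read-out. Nothing available here bears on what lies behind these two small steps.

On these data alone, what remains open is whether any other group in the place of the chloro, such as an amine or a carboxylic acid, would move the number beyond the scatter. Equally open is whether a longer chain in the place of the methoxy group would do so, since the two steps shown cover only chloro and methoxy, each set against hydrogen.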